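The source may hold more compounds than are shown below. What is called first, only, known or untested is meant among the compounds shown, and "the series" means these compounds.

Of the compounds shown here, three that share one core have been tested in an ADME assay on microsomes from liver (Homo sapiens) for metabolic stability, with a stated time of 30 min; on this read-out higher numbers stand for a more stable compound and lower numbers for a less stable compound. Compound 1 `CCCCc1nc(C(C)C)c(CC(=O)OCC(C)C)c(=O)n1Cc1ccc(-c2ccccc2-c2noc(=O)[nH]2)cc1` gives 8.8%. Compound 2 `CCCCOC(=O)Cc1c(C)nc(CCCC)n(Cc2ccc(-c3ccccc3-c3noc(=O)[nH]3)cc2)c1=O` gives 2.8%. Compound 3 `CCCCc1nc(C)c(CC(=O)OCC(C)C)c(=O)n1Cc1ccc(-c2ccccc2-c2noc(=O)[nH]2)cc1` gives 2.4%, the lowest of the three numbers, though the two others stand within the usual scatter of it.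

The two comparisons that end at compound 3 are both small. The change a number 6.4 percentage points lower from compound 1 to compound 3 (within the scatter) concerns methyl in place of isopropyl on an aromatic carbon. The change a number 0.4 percentage points lower from compound 2 to compound 3 (within the scatter) concerns isopropyl in place of propyl on a saturated chain carbon bound to an oxygen next to a carbonyl group.

Compound 4 `CCCCc1nc(C)c(CC(=O)OCC2CCCCC2)c(=O)n1Cc1ccc(-c2ccccc2-c2noc(=O)[nH]2)cc1` has not yet been measured in this assay. It differs from compound 3 by cyclohexyl in place of isopropyl on a saturated chain carbon bound to an oxygen next to a carbonyl group. Of the measured steps, only a number 0.4 percentage points lower from compound 2 to compound 3 (within the scatter) touches the same place, and it stayed within the scatter; the larger group now entering has no precedent among these compounds. The expected step is therefore a number 1.1 percentage points higher from compound 3 to compound 4 (within the scatter), none beyond the scatter in either direction. In this assay compound 4 is estimated at 3.5%, with a range from 0.5% to 14%.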

Compound 4, percent of the compound remaining: 11.5%
Compound 4: the middle estimate sits 8 percentage points below what was measured, within the range that was stated.
By their numbers in this assay, from the lowest: compounds 3, 2, 1 and 4 (each within the scatter of the next).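

In this assay, among the compounds shown here, the place on a saturated chain carbon bound to an oxygen next to a carbonyl group carries a ring for the first time: cyclohexyl in place of isopropyl gives a number 9.1 percentage points higher from compound 3 to compound 4 (within the scatter) and cyclohexyl in place of propyl gives a number 8.7 percentage points higher from compound 2 to compound 4 (within the scatter) as the matching comparison with the straight chain. These are the largest steps yet seen at this place, but both remain inside the usual scatter, so the cyclohexyl group cannot yet be told apart from the two smaller groups here. Nothing else measured on these compounds helps to explain the numbers.

On these data alone, it remains open whether a group of another kind at this place, such as an amine, a carboxylic acid or a phenyl ring, would give a step beyond the scatter. It is also unknown whether cyclohexyl would behave the same way on the isopropyl-bearing core of compound 1, since only the core with methyl on the aromatic carbon carries it here.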